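Working notes: nitro in place of hydrogen, compound 2 to compound 3

This account rests on a few compounds, and the source may have more. Where it says the series, first, only, none or still open, it means among the compounds named here.

Compound 1 `COc1ccc2[nH]c(=O)c(-c3nc4cc(F)ccc4[nH]3)cc2c1` — > 100000 nM
Compound 2 `COc1ccc2[nH]c(=O)c(-c3nc4ccccc4[nH]3)cc2c1` — > 100000 nM

In an ADME assay on L02 cells (Homo sapiens) for cytotoxicity, read by MTT assay, with a stated time of 48 h (a lower number here means a stronger inhibitor, a higher number a weaker inhibitor), compound 1 gives only the limit > 100000 nM. Compound 2 gives only the limit > 100000 nM. The step that the two limits leave unreadable from compound 1 to compound 2 cannot be read, since both values sit at the limit of > 100000 nM in this assay, at which 2 of the 2 values shown sit. Compound 3 `COc1ccc2[nH]c(=O)c(-c3nc4cc([N+](=O)[O-])ccc4[nH]3)cc2c1` differs from compound 2 by nitro in place of hydrogen on an aromatic carbon. For the measured compounds named here, no measured step gives a readable size, so the expectation for compound 3 rests on compound 2 standing at the limit; the step that the limit leaves unreadable from compound 2 to compound 3 is expected to lie within the scatter. Compound 3 is estimated at 150000 nM, range 60000 nM to 400000 nM, most likely reported again only as a limit.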

Compound 3, half-maximal inhibitory concentration: > 100000 nM
Compound 3: only a limit was reported; the forecaster's own chance of this, stated with the estimate: 80%; the middle value is on the limit's open side.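

No step among compound 1, compound 2 and compound 3 can be read in this assay, as each value is only a limit: the limit of > 100000 nM in this assay, at which 3 of the 3 values shown sit.

Going by these compounds, whether fluoro, hydrogen and nitro on the shared core differ at all in this assay stays open.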